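This account rests on a few compounds, and the source may have more. Where it says the series, first, only, none or still open, it means among the compounds named here.

Measured compounds:
compound 1, `CN(C)CCCNc1nc(-c2ccc(NC(=O)Nc3ccc(F)cc3)cc2)nc2c(Cl)c(Cl)sc12`: 1120 nM
compound 2, `CN(C)CCCNc1nc(-c2ccc(NC(=O)Nc3ccccc3Cl)cc2)nc2c(Cl)c(Cl)sc12`: 1330 nM

In a functional assay on MKN-45 cells (Homo sapiens) for cytotoxicity, read by MTT assay, with a stated time of 72 h (a higher number here means a weaker inhibitor, a lower number a stronger inhibitor), compound 2 gives 1330 nM, and compound 1 gives 1120 nM. For the measured compounds named here, these two numbers are the only ones available, and they sit within the usual scatter of each other: the one step between them, a 1.2-fold higher number from compound 1 to compound 2 (0.07 log units; within the scatter), is too small to count as a real difference. Both compounds share the same core and differ only in the aryl group attached to an amide-type nitrogen.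

Compound 3, `Cc1ccc(NC(=O)Nc2ccc(-c3nc(NCCCN(C)C)c4sc(Cl)c(Cl)c4n3)cc2)cc1`, keeps that core and changes the same position once more: 4-methylphenyl in place of 2-chlorophenyl on an amide-type nitrogen. Going by the values given here, the only measured step that bears on this change is the one from compound 1 to compound 2, which also swapped one aryl group for another on that nitrogen and stayed within the scatter. On that basis the move to compound 3 is expected to bring no step beyond the scatter, a 1.0-fold lower number from compound 2 to compound 3 (0.01 log units; within the scatter), in either direction. The number for compound 3 in this assay is therefore estimated at 1300 nM, with a range from 600 nM to 2800 nM.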

Compound 3, half-maximal inhibitory concentration: 3700 nM
Compound 3: the middle estimate sits 2.8-fold (0.45 log units) below what was measured; measured number outside the range, above it.
By their numbers in this assay, from the lowest: compounds 1 and 2 (each within the scatter of the next); then compound 3.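

In this assay, the aryl group on this amide-type nitrogen turns out to matter: 4-methylphenyl in place of 2-chlorophenyl gives a 2.8-fold higher number from compound 2 to compound 3 (0.44 log units; beyond the scatter), whereas the earlier swap between two halogen-bearing aryl groups left no readable difference. The comparison with compound 1 is the cleaner one. Only methyl in place of fluoro on an aromatic carbon separates the two compounds, and that single change gives a 3.3-fold higher number from compound 1 to compound 3 (0.52 log units; beyond the scatter), so compound 3 stands as the weakest of the three in this cell assay. No measurement shown here accounts for this loss of activity.

The compounds shown leave open whether the higher number is particular to methyl or would also appear with other groups, such as methoxy or trifluoromethyl, on the aryl ring. A 4-chlorophenyl or an unsubstituted phenyl group on the same nitrogen would also help to show whether the identity of the group or its place on the ring sets the number.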